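Swapping a Halogenated Benzyl for a Methoxyphenoxy Ether

This account rests on a few compounds, and the source may have more. Where it says the series, first, only, none or still open, it means among the compounds named here.

Among the measured compounds shown here, compound 2 `COc1cccc(CNCCCNc2ccnc3cc(Cc4ccc(F)cc4Cl)ccc23)c1O` gives 23 10^-6 cm/s in an ADME assay for permeability, using PAMPA, with a stated time of 30 min, at pH 7.4 (on this read-out higher numbers stand for higher permeability and lower numbers for lower permeability), the lowest of the two numbers measured so far; compound 1 `COc1cccc(CNCCCNc2ccnc3cc(-c4ccc(C(F)(F)F)cc4)ccc23)c1O` gives 237 10^-6 cm/s, and the step of a 10-fold lower number from compound 1 to compound 2 (1.01 log units; beyond the scatter) separates the two. Compound 3 `COc1ccccc1Oc1ccc2c(NCCCNCc3cccc(OC)c3O)ccnc2c1` alters compound 2 at a single place: 2-methoxyphenoxy in place of 2-chloro-4-fluorobenzyl on an aromatic carbon. For the measured compounds named here, no measured step involves a 2-methoxyphenoxy group, so the one step known, from compound 1 to compound 2, shows only how far a single change on an aromatic carbon can move this assay. Compound 3 is therefore expected to give 15 10^-6 cm/s, within 4 10^-6 cm/s to 60 10^-6 cm/s, an expected step of a 1.5-fold lower number from compound 2 to compound 3 (0.19 log units; within the scatter).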

Compound 3, apparent permeability: 317 10^-6 cm/s
For compound 3 the middle estimate is 21-fold (1.32 log units) below the measured one, and the stated range ends below it.
By their numbers in this assay, from the lowest: compound 2; then compounds 1 and 3 (each within the scatter of the next).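

Putting 2-methoxyphenoxy in place of 2-chloro-4-fluorobenzyl on this aromatic carbon brings a 14-fold higher number from compound 2 to compound 3 (1.14 log units; beyond the scatter) in this assay even though both groups have the same number of heavy atoms and one carbon-only aromatic ring. Against 4-(trifluoromethyl)phenyl, the same group gives a 1.3-fold higher number from compound 1 to compound 3 (0.13 log units; within the scatter) so, of the three compounds, only compound 2 stands apart. Nothing measured here offers a reason for these steps. As far as these compounds go, whether the linking atom or the ring's substituents set the number stays open, and an unsubstituted phenoxy group or a ring joined through an amine on this carbon would speak to that.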